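What Removing the (4-Fluorobenzyl)sulfanyl Group Might Cost

The source may hold more compounds than are shown below. What is called first, only, known or untested is meant among the compounds shown, and "the series" means these compounds.

Three compounds have been measured in a functional assay on PC-9 cells (Homo sapiens) for inhibition, read by MTT assay, with a stated time of 72 h; a higher number here means a weaker inhibitor, a lower number a stronger inhibitor:

Compound 1, `Cc1cc(Nc2cc(-c3ccccc3)[nH]n2)n2nc(SCc3ccc(F)cc3)nc2n1`: 8110 nM
Compound 2, `Cc1cc(Nc2ccn(Cc3cccc4ccccc34)n2)n2nc(SCc3ccc(Br)cc3)nc2n1`: 5660 nM
Compound 3, `Cc1cc(Nc2cc(C(C)(C)C)[nH]n2)n2nc(SCc3ccc(Br)cc3)nc2n1`: 12400 nM

The three numbers lie close together. Compound 1 differs from compound 2 and from compound 3 by less than the usual scatter in each case, so nothing separates the three on this evidence; all are modest inhibitors.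

Compound 4, `Cc1cc(Nc2cc(-c3ccccc3)[nH]n2)n2ncnc2n1`, differs from compound 1 in one place: hydrogen in place of (4-fluorobenzyl)sulfanyl on an aromatic carbon. Among the compounds with values here, no measured pair shows this change, so the expected size of the step rests on compound 1's value alone and on the nature of the change, which strips away a complete group and leaves only hydrogen. The other two compounds each keep a group of the same kind at that place, and none of the three reaches a low number even with it. The expectation is therefore that the loss moves compound 4 toward a weaker inhibitor, with a step expected to be a 2.0-fold higher number from compound 1 to compound 4 (0.30 log units; within the scatter), somewhat beyond the scatter though not dramatically so. It is possible that this assay reports only a limit for compound 4. Compound 4 is estimated at 16000 nM, with a range from 6000 nM to 45000 nM.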

Compound 4, half-maximal inhibitory concentration: > 50000 nM
Compound 4 was reported as a limit; the forecaster's own chance of this, stated with the estimate: 25%; at least 3.1-fold (0.49 log units) between middle value and limit.
By their numbers in this assay, from the lowest: compounds 2, 1 and 3 (each within the scatter of the next, the first and the last beyond it). At a limit, above all of these: compound 4.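

In this assay, compound 4 is recorded only as a limit, > 50000 nM, and not as a number. Within the data shown here, replacing the (4-fluorobenzyl)sulfanyl group with hydrogen gives an at least 6.1-fold higher number from compound 1 to compound 4 (0.78 log units; beyond the scatter), a step beyond the scatter, and this is the first direct evidence that the substituent on this aromatic carbon, between two ring nitrogen atoms, matters for the read-out; the earlier compounds all kept a group of this kind at that place, so they could not show what its loss costs. The true size of the step remains unknown and rests on this single pair, with only its lower bound fixed by the top of the measured range: the limit of > 50000 nM in this assay, at which 1 of the 4 values shown sits.

The compounds shown leave open which part of the group carries the effect, and whether a methylsulfanyl group, an amine or a bare benzyl group on the same carbon would keep the value of compound 1 or fall away as hydrogen does. They also leave open whether the same removal would cost as much with the other substituents seen on the pyrazole-bearing side of compound 2 and compound 3.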